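A larger group on the ring nitrogen of compound 2

A few compounds are considered here, and "the series" means these few. Any claim that something is new, unique, unknown or untested is made for them only; others in the source may bear on it.

Compound 2 `CCOC(=O)c1[nH]c(-c2cccc(C#N)c2)nc1C`, compound 1 `CCOC(=O)c1c(C)nc(-c2cccc(C#N)c2)n1O` and compound 3 `CCOC(=O)c1c(C)nc(-c2cccc(C#N)c2)n1C(C)C` share one core and differ only at a single aromatic nitrogen. In a functional assay on a cell-free system (plasma, Oryctolagus cuniculus) for inhibition, with stated times of 5 min, 1 min and 6 min (a lower number here means a stronger inhibitor, a higher number a weaker inhibitor), compound 2 reaches only > 30000 nM, which is a limit of the assay and not a number. Compound 1 gives 17600 nM and compound 3 gives 9260 nM in this assay. The change to compound 4 `CCOC(=O)c1c(C)nc(-c2cccc(C#N)c2)n1OCc1ccccc1F` is (2-fluorobenzyl)oxy in place of hydrogen on an aromatic nitrogen. The measured steps at the same nitrogen are an at least 3.2-fold lower number from compound 2 to compound 3 (0.51 log units; beyond the scatter), an at least 1.7-fold higher number from compound 1 to compound 2 (0.23 log units; that floor lies within the scatter) and a 1.9-fold lower number from compound 1 to compound 3 (0.28 log units; within the scatter). Since a group on this nitrogen lowered the number beyond the scatter in an at least 3.2-fold lower number from compound 2 to compound 3 (0.51 log units; beyond the scatter), compound 4 is expected to show a clear step of an at least 6.0-fold lower number from compound 2 to compound 4 (0.77 log units; beyond the scatter). Compound 4 is estimated at 5000 nM, between 1500 nM and 20000 nM.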

Compound 4, half-maximal inhibitory concentration: 8990 nM
Compound 4: the middle estimate sits 1.8-fold (0.25 log units) below what was measured, and the stated range covers the measured number.
By their numbers in this assay, from the lowest: compounds 4, 3 and 1 (each within the scatter of the next). At a limit, above all of these: compound 2.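

In this assay, (2-fluorobenzyl)oxy on the aromatic nitrogen gives an at least 3.3-fold lower number from compound 2 to compound 4 (0.52 log units; beyond the scatter), but compound 2 stands only at a limit, so this step is a floor. Against the other two groups no difference appears: a 1.0-fold lower number from compound 3 to compound 4 (0.01 log units; within the scatter), and a 2.0-fold lower number from compound 1 to compound 4 (0.29 log units; within the scatter). Among these compounds, an added aromatic ring on this nitrogen therefore brings compound 4 level with compound 3 and compound 1, with no separate step of its own. Going by these compounds, whether an amine or a carboxylic acid at this nitrogen would move the number beyond the scatter remains open, as does the actual value of compound 2.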